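The compounds below may be only part of what the source reports. "The series", "measured", "known", "first", "only" and "open" are said of these compounds alone.

Measured so far in a functional assay on A549 cells (Homo sapiens) for inhibition, read by MTT assay, with a stated time of 72 h; a higher number here means a weaker inhibitor, a lower number a stronger inhibitor:
- compound 1 `CO[C@@H]1[C@H]2OC(=O)C[C@H]2O[C@@H]1[C@@H](O)c1ccccc1` gives 38300 nM
- compound 2 `CO[C@@H]1[C@H]2OC(=O)C[C@H]2O[C@@H]1C(=O)c1ccccc1` gives 2580 nM

Compound 1 carries the higher of the two numbers, which makes it the weaker inhibitor of the pair, and compound 2 sits lower by more than the usual scatter. The next molecule is compound 3 `CO[C@@H]1[C@H]2OC(=O)C[C@H]2O[C@@H]1[C@H](O)c1ccccc1`, which keeps everything in compound 1 except its spatial arrangement at one point: the two compounds have the same atoms and bonds and differ only in configuration as drawn: 1 of 5 stereo elements differ; a stereocentre at a saturated chain carbon is drawn S in compound 1 and R in compound 3 (a stereocentre at a saturated chain carbon is drawn S in compound 1 and R in compound 3). For the measured compounds named here, no measured pair shows what changing a single stereocentre does in this assay, so the closest guide is compound 1 itself at 38300 nM and the forecast stays uncertain. A modest 1.9-fold lower number from compound 1 to compound 3 (0.28 log units; within the scatter) is expected, towards a lower number and near the edge of the scatter. For compound 3 the estimated value is 20000 nM, with an expected range from 5000 nM to 60000 nM in this test.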

Compound 3, half-maximal inhibitory concentration: 23600 nM
Estimate against measurement, compound 3: 1.2-fold (0.07 log units) below; low and high end bracket the measured number.
By their numbers in this assay, from the lowest: compound 2; then compounds 3 and 1 (each within the scatter of the next).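

For the compounds shown here, this pair gives the first direct reading of what changing a single stereocentre does in this assay: redrawing the stereocentre at a saturated chain carbon from S to R gives a 1.6-fold lower number from compound 1 to compound 3 (0.21 log units; within the scatter). That step stays within the usual scatter of repeated measurements, so compound 1 and compound 3 cannot be told apart here, and the drawn configuration at this carbon shows no clear effect on the read-out. The comparison isolates this one point: the fact that compounds 1 and 3 differ only in the configuration as drawn

Still open, from the compounds shown here alone, is whether the other stereocentres of the shared core would behave the same way. Also open, going by these compounds, is how an amine or a carboxylic acid at this same carbon would read in this assay, in place of what compound 1 and compound 3 carry there.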